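The compounds below may be only part of what the source reports. "The series", "measured", "known", "first", "only" and "open" are said of these compounds alone.

Measured so far in a functional assay on U2OS cells (Homo sapiens) for inhibition, read by CCK-8 assay, with a stated time of 72 h, tested at 1 uM; a lower number here means less inhibition, a higher number more inhibition at the concentration tested (going by the name of the read-out):
compound 1 `COc1ccc(OC)c(N2C(=O)CSC2c2cccc(C(=O)NCCCCc3ccccc3)c2)c1` gives 1%;
compound 2 `COc1ccccc1N1C(=O)CSC1C(=O)NCCCCc1ccccc1` gives 6%;
compound 3 `O=C(NCCCCc1ccccc1)c1cccc(C2SCC(=O)N2c2ccccc2)c1` gives 68%.

Compound 3 stands highest of the three, with compound 2 far below it and compound 1 furthest below. The next compound, compound 4 `COc1cccc(OC)c1N1C(=O)CSC1c1cccc(C(=O)NCCCCc2ccccc2)c1`, differs from compound 3 in one place: 2,6-dimethoxyphenyl in place of phenyl on an amide-type nitrogen in a ring. Within the data shown here, the one step that bears on this is the one in which two methoxy groups left the same phenyl ring, a number 67 percentage points higher from compound 1 to compound 3 (beyond the scatter), a large gain. Compound 4 puts two methoxy groups back onto that ring, so the reverse, a large loss, is expected, though the methoxy pattern is not identical. The estimated step is a number 53 percentage points lower from compound 3 to compound 4 (beyond the scatter). Compound 4 is therefore expected to give 15%, within 0% to 45%.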

Compound 4, a percentage reported as inhibition, at one concentration (the size of the read-out at that concentration, not a potency): 41%
Estimate against measurement, compound 4: 26 percentage points below; the range from low to high includes it.
By their numbers in this assay, from the lowest: compounds 1 and 2 (each within the scatter of the next); then compound 4; then compound 3.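

Two methoxy groups on this phenyl ring do not carry one fixed cost. Placing 2,6-dimethoxyphenyl in place of phenyl on the amide-type nitrogen lowers the number modestly (a number 27 percentage points lower from compound 3 to compound 4 (beyond the scatter)), yet the same group in place of 2,5-dimethoxyphenyl raises it largely (a number 40 percentage points higher from compound 1 to compound 4 (beyond the scatter)), so the arrangement of the methoxy groups matters as well as their presence. Nothing at hand explains this difference.

Among these compounds, still open is how a ring carrying only one methoxy group, a fluorine atom or an amine would compare with compound 3. The three ring patterns compared here cannot settle that.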